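The source may report more compounds than this note shows. Statements on the series, on what has been measured and on what is new or still open speak of the compounds shown alone.

Compound 2 `Cc1cc(C#N)cc(C)c1Oc1nc(Nc2ccc(C#N)cc2)ncc1/C=C/C(=O)N1CCN(C(=O)C(F)(F)F)CC1` sits at a limit of an ADME assay on TZM cells (Homo sapiens) for cytotoxicity, with a stated time of 1 days (on this read-out lower numbers stand for higher toxicity in this test and higher numbers for lower toxicity in this test), giving > 174 nM, so no number for it is known. Compound 1 `Cc1cc(C#N)cc(C)c1Oc1nc(Nc2ccc(C#N)cc2)ncc1/C=C/C(=O)NCC1CCN(S(C)(=O)=O)C1` likewise reaches only a limit, > 175 nM. The step that the two limits leave unreadable from compound 1 to compound 2 therefore cannot be read. Compound 3 `CC(=O)N1CCN(C(=O)/C=C/c2cnc(Nc3ccc(C#N)cc3)nc2Oc2c(C)cc(C#N)cc2C)CC1` differs from compound 2 by methyl in place of trifluoromethyl on a carbonyl carbon. Going by the values given here, no measured step bears on this change, and both limits the limit of > 174 nM in this assay, at which 1 of the 2 values shown sits, and the limit of > 175 nM in this assay, at which 1 of the 2 values shown sits, leave it unread, so for compound 3 no step beyond the scatter is expected, and a further limit is the likeliest outcome. Compound 3 is estimated at 300 nM (range 150 nM to 1200 nM), an expected step that the limit leaves unreadable from compound 2 to compound 3.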

Compound 3, half-maximal cytotoxic concentration: > 192 nM
Compound 3: a limit, no number; the forecaster's own chance of this, stated with the estimate: 85%; the middle value is on the limit's open side.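

Going by these compounds alone, compound 3, like compound 1 and compound 2, reaches only a limit in this assay, so no step among the three can be read. The compounds shown leave open where each one's true half-maximal cytotoxic concentration lies, and whether trifluoromethyl or methyl on the carbonyl carbon makes any difference.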